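The compounds below may be only part of what the source reports. "The series", "measured", "known", "first", "only" and "open" are said of these compounds alone.

Working notes on the series. Compound 1, `CNC[C@]1(OC)Cc2ccccc2[C@@H]1Oc1ccccc1C`, gives in an in vitro assay on HEK293 cells for inhibition of sodium-dependent dopamine transporter (Homo sapiens) (a lower number here means a stronger inhibitor, a higher number a weaker inhibitor), only a limit, > 10000 nM. Compound 2, `CNC[C@]1(O)Cc2ccccc2[C@@H]1Oc1ccccc1CO`, likewise returns in this assay only a limit, > 10000 nM. Compound 2 therefore stands at the same place as compound 1, and the evidence so far is the limit of > 10000 nM in this assay, at which 2 of the 2 values shown sit. Compound 3, `CNC[C@]1(O)Cc2ccccc2[C@@H]1Oc1ccccc1Cl`, is not yet measured and differs from compound 2 by chloro in place of hydroxymethyl on an aromatic carbon. Within the data shown here, no step between measured compounds is available, so the size of this change cannot be read from the data. In this assay compound 3 is expected to remain at the limit, with an estimated step that the limit leaves unreadable from compound 2 to compound 3. The estimate for compound 3 is 15000 nM, ranging from 3000 nM to 60000 nM.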

Compound 3, half-maximal inhibitory concentration: 10000 nM
Compound 3: middle estimate off by 1.5-fold (0.18 log units), on the high side; the range from low to high includes it.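

Chloro in place of hydroxymethyl on this aromatic carbon, ortho to a large group, gives in this assay a number no higher from compound 2 to compound 3 (the limit leaves the size open). This is the only plain number shown so far: in this assay, compound 3 gives 10000 nM. Compound 2 remains a limit at > 10000 nM, so the size of the step cannot be read. The series still sits at the edge of the readable range: the limit of > 10000 nM in this assay, at which 2 of the 3 values shown sit.

The compounds shown leave open whether a nitrile or an amine on this aromatic carbon would give a lower number in this assay.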